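The compounds below may be only part of what the source reports. "The series", "measured", "known", "first", "only" and "open" are said of these compounds alone.

Compound 3 `CC1CCN(c2c(S(=O)(=O)c3cccc(F)c3)cnc3c(F)cccc23)CC1` gives 62% in an assay on isolated protein for displacement of a labelled ligand from metabotropic glutamate receptor 5 (Homo sapiens), with a stated time of 60 min, tested at 1 uM (a lower number here means less inhibition, a higher number more inhibition at the concentration tested (going by the name of the read-out)), and stands lowest of the three measured compounds, while compound 1 `CC1CCN(c2c(S(=O)(=O)c3ccc(F)c(F)c3)cnc3c(F)cccc23)CC1` gives 93% and compound 2 `Cc1ccc(S(=O)(=O)c2cnc3c(F)cccc3c2N2CCC(C)CC2)cc1` gives 93% in this assay. Compound 4 `CC1CCN(c2c(S(=O)(=O)c3ccc(F)c(Cl)c3)cnc3c(F)cccc23)CC1` differs from compound 3 in one place: 3-chloro-4-fluorophenyl in place of 3-fluorophenyl on a sulfonyl sulfur. Going by the values given here, two measured steps bear on this change. The step of a number 31 percentage points lower from compound 2 to compound 3 (beyond the scatter) shows the 3-fluorophenyl group falling well short of the 4-methylphenyl group, and the step of a number 31 percentage points lower from compound 1 to compound 3 (beyond the scatter) shows the same loss when a fluoro on an aromatic carbon is removed. Compound 4 returns to a 3,4-disubstituted phenyl on the sulfonyl sulfur, close in kind to compound 1, so a large rise is expected, a number 26 percentage points higher from compound 3 to compound 4 (beyond the scatter). Compound 4 is therefore estimated at 88%, with a range from 70% to 98%.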

Compound 4, a percentage reported as inhibition, at one concentration (the size of the read-out at that concentration, not a potency): 95%
The estimate for compound 4 lay 7 percentage points below the measured number; the range from low to high includes it.
By their numbers in this assay, from the lowest: compound 3; then compounds 1, 2 and 4 (each within the scatter of the next).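

Replacing 3-fluorophenyl with 3-chloro-4-fluorophenyl on the sulfonyl sulfur gives a number 33 percentage points higher from compound 3 to compound 4 (beyond the scatter) in this assay. Chloro in place of fluoro on an aromatic carbon gives a number 2 percentage points higher from compound 1 to compound 4 (within the scatter), and the change from 4-methylphenyl gives a number 2 percentage points higher from compound 2 to compound 4 (within the scatter), so the number is level across compounds 1, 2 and 4, while only compound 3, with its 3-fluorophenyl, is lower. No measured evidence explains this difference. As far as these compounds go, it remains open how a phenyl carrying a methoxy group or an amine would read at this position, and whether the numbers of compounds 1, 2 and 4 would separate at another concentration.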